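The source may report more compounds than this note shows. Statements on the series, on what has been measured and on what is new or still open speak of the compounds shown alone.

In an ADME assay on NCM460 cells (Homo sapiens) for cytotoxicity, read by CCK-8 assay, with a stated time of 48 h (on this read-out lower numbers stand for stronger inhibition and higher numbers for weaker inhibition), two compounds with a shared core have been measured so far: compound 1 `COc1ccc(/C=C\c2cc(OC)c(OC)c(OC)c2)cc1OCc1ccc(CNCCO)cc1` gives 39000 nM and compound 2 `COc1ccc(/C=C\c2cc(OC)c(OC)c(OC)c2)cc1OCc1ccc(CNCCN(C)C)cc1` gives 35000 nM there, so compound 2 stands level with compound 1 within the scatter. Compound 3 `COc1ccc(/C=C\c2cc(OC)c(OC)c(OC)c2)cc1OCc1ccc(CN2CCCCC2C(=O)NCCN)cc1` keeps that core, but 2-((2-aminoethyl)carbamoyl)piperidin-1-yl takes the place of (2-(dimethylamino)ethyl)amino on a saturated chain carbon bound to an aromatic carbon, a change counted as 2-((2-aminoethyl)carbamoyl)piperidin-1-yl in place of (2-(dimethylamino)ethyl)amino on a saturated chain carbon bound to an aromatic carbon in full. Within the data shown here, only one measured step bears on this, namely a 1.1-fold lower number from compound 1 to compound 2 (0.05 log units; within the scatter) within the side chain, and it stays within the scatter. Among the measured compounds shown here, no measured compound carries a ring or an amide in this side chain, so that evidence is thin. The expected step, a 1.2-fold lower number from compound 2 to compound 3 (0.07 log units; within the scatter) as estimated, is no larger than the scatter, and no firm direction is expected. For compound 3 the estimated value is 30000 nM with an expected range from 12000 nM to 70000 nM on this read-out.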

Compound 3, half-maximal inhibitory concentration: > 50000 nM
Compound 3: only a limit was reported; the forecaster's own chance of this, stated with the estimate: 15%; middle value at least 1.6-fold (0.22 log units) away from the limit.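

The new side chain, 2-((2-aminoethyl)carbamoyl)piperidin-1-yl, is the only one shown with a ring and an amide on this saturated chain carbon bound to an aromatic carbon, and with it compound 3 reaches a limit of this assay rather than a number: the limit of > 50000 nM in this assay, at which 1 of the 3 values shown sits.

The steps to it are therefore floors only: there is an at least 1.4-fold higher number from compound 2 to compound 3 (0.15 log units; that floor lies within the scatter), and there is an at least 1.2-fold higher number from compound 1 to compound 3 (0.10 log units; that floor lies within the scatter). This much larger group gives no sign of a lower number than the two open chains, yet these floors alone do not establish a real weakening.

Still open, on these data alone, is which part of the new group matters, since a plain piperidin-1-yl or a carboxylic acid in place of the amide would separate the ring from the aminoethyl arm. Also open, as far as these compounds go, is whether any group here can bring a number clearly lower than those of compound 1 and compound 2 in this assay.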